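A few compounds are considered here, and "the series" means these few. Any claim that something is new, unique, unknown or untested is made for them only; others in the source may bear on it.

Of the compounds shown here, two have so far been measured in a physicochemical assay for lipophilicity, using the shake flask method, at pH 7.4; a lower number here means a more polar compound, a higher number a more lipophilic compound. Compound 1 `CCCC(Oc1ccc(-n2cc(OC)cn2)cc1)c1ccc(C(=O)NCCC(=O)O)cc1` gives 1.4. Compound 2 `CCC(Oc1ccc(-n2cc(C(F)(F)F)cn2)cc1)c1ccc(C(=O)NCCC(=O)O)cc1` gives 1.9, the higher of the two numbers, and its gap to compound 1 lies beyond the scatter. Compound 3 `CCCC(Oc1ccc(-n2cc(C(F)(F)F)cn2)cc1)c1ccc(C(=O)NCCC(=O)O)cc1` has not yet been measured. It differs from compound 2 by methyl in place of hydrogen on a saturated chain carbon, three bonds along the chain from an aromatic carbon and an oxygen on an aromatic ring. For the measured compounds named here, no measured pair shows this same change, so the size of the step cannot be read from a measured pair; it rests on the change itself. Compound 3 is expected to give a higher number than compound 2 in this assay, by a small step that should reach just beyond the scatter rather than stay within it. For compound 3 the estimate is 2.3, with a range from 1.9 to 2.7. The expected step is a number 0.40 log units higher from compound 2 to compound 3 (beyond the scatter).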

Compound 3, distribution coefficient: 2.4
Compound 3: the middle estimate sits 0.10 log units below what was measured; the range from low to high includes it.
By their numbers in this assay, from the lowest: compound 1; then compound 2; then compound 3.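

In this assay, for the compounds shown here, the change from ethyl to propyl gives a number 0.50 log units higher from compound 2 to compound 3 (beyond the scatter) and so has a measured size at this place on the chain for the first time. Going by these compounds alone, compound 3 also differs from compound 1 in one place only, and there trifluoromethyl in place of methoxy on an aromatic carbon gives a number 1.00 log units higher from compound 1 to compound 3 (beyond the scatter) as the first reading of that change. No measurement at hand bears on why either step has its size.

From the compounds shown here alone, each step rests on a single pair, so it remains open whether the chain step would be the same with methoxy on the aromatic carbon. Also open, going by these compounds, is how a longer chain such as butyl, or a nitrile or an amine in place of trifluoromethyl, would read in this assay on the same core.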